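The source may hold more compounds than are shown below. What is called first, only, known or untested is meant among the compounds shown, and "the series" means these compounds.

Measured compounds:
compound 1, `Clc1ccc(C(c2ccccc2)(c2ccc(CN3CCCC3)cc2)n2ccnc2)cc1`: 70.3 uM
compound 2, `Fc1ccc(C(c2ccc(Cl)cc2)(c2ccc(CN3CCCC3)cc2)n2ccnc2)cc1`: "not determined" (no result reported)

In an ADME assay on cells (Lymphocyte, Homo sapiens) for cytotoxicity, read by MTT assay, with a stated time of 48 h (on this read-out lower numbers stand for higher toxicity in this test and higher numbers for lower toxicity in this test), compound 1 gives 70.3 uM. Among the measured compounds shown here, compound 2 shares the core of compound 1 but carries a fluoro group where compound 1 has no substituent; for compound 2 no number was reported in this assay, so its standing cannot be placed on any scale, and the only measured anchor is compound 1.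

Compound 3, `Clc1ccc(C(c2ccc(CN3CCCC3)cc2)(c2ccc(CN3CCCC3)cc2)n2ccnc2)cc1`, has not yet been measured. It differs from compound 2 in one place: (pyrrolidin-1-yl)methyl in place of fluoro on an aromatic carbon. The result is a molecule carrying two (pyrrolidin-1-yl)methyl groups instead of one.

For the measured compounds named here, since no step between measured compounds is available, the size and direction of this change in this assay cannot be read from the data. The expectation is a modest move toward a lower number than compound 1, that is toward somewhat higher toxicity in this test, but with wide uncertainty. For compound 3 in this assay a value of about 40 uM is expected, with a likely range from 15 uM to 110 uM.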

Compound 3, half-maximal toxic concentration: 68.5 uM
Compound 3: middle estimate off by 1.7-fold (0.23 log units), on the low side; low and high end bracket the measured number.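

In this assay, among the compounds shown here, placing a (pyrrolidin-1-yl)methyl group on an aromatic carbon where compound 1 has hydrogen gives a 1.0-fold lower number from compound 1 to compound 3 (0.01 log units; within the scatter), the first step that can be read at this position. The step shows that a second (pyrrolidin-1-yl)methyl group, with its five-membered non-aromatic ring, leaves the read-out within the usual scatter, so for this pair the larger group brings no measurable change in toxicity in this test. Nothing available bears on why the read-out stays level.

From the compounds shown here alone, the steps that involve compound 2 cannot be read, as it has no reported number, so how a fluoro group at this position compares with hydrogen or with (pyrrolidin-1-yl)methyl remains unknown. Going by these compounds, it is also open whether another group here, such as a carboxylic acid, a simple dimethylamine on the same methylene or a longer chain ending in pyrrolidine, would likewise stay within the scatter, since this single step cannot be extended to groups beyond this pair.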